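The source may report more compounds than this note shows. Statements on the series, on what has been measured and on what is new or still open speak of the compounds shown alone.

In a toxicity assay on MT2 cells (Homo sapiens) for cytotoxicity, read by XTT assay, with a stated time of 4 days (on this read-out lower numbers stand for higher toxicity in this test and higher numbers for lower toxicity in this test), compound 2 `Cc1nc(C)c([C@H](OC(C)(C)C)C(=O)O)c(N2CCC(C)(C)CC2)c1-c1ccc(OCCc2cc(F)c(F)cc2F)cc1` gives >= 33500 nM, which is a limit and not a number. Compound 1 `Cc1nc(C)c([C@H](OC(C)(C)C)C(=O)O)c(N2CCC(C)(C)CC2)c1-c1ccc(OCCc2ccc(F)cc2F)cc1` gives >= 33500 nM, also a limit. Going by the values given here, the series so far therefore stands at the limit of >= 33500 nM in this assay, at which 2 of the 2 values shown sit, and compound 2 has no readable position beyond that.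

Compound 3 `Cc1nc(C)c([C@H](OC(C)(C)C)C(=O)O)c(N2CCC(C)(C)CC2)c1-c1ccc(OCCc2ccccn2)cc1` carries pyridin-2-yl in place of 2,4,5-trifluorophenyl on a saturated chain carbon, two bonds along the chain from an oxygen on an aromatic ring.

Among the compounds with values here, only one measured step bears on this change: a step that the two limits leave unreadable from compound 1 to compound 2. It alters the fluoro substitution of the aromatic ring that now leaves, and its size cannot be read. Within the data shown here, no measured step exchanges that ring for a pyridinyl one, so the support is thin. With both neighbours sitting at the limit of >= 33500 nM in this assay, at which 2 of the 2 values shown sit, no step beyond the usual scatter is expected, and a reading at the same limit is the likeliest outcome. The expected change is an at least 1.1-fold lower number from compound 2 to compound 3 (0.04 log units; that floor lies within the scatter). For compound 3 the estimate in this assay is 30000 nM, with an expected range from 14000 nM to 40000 nM.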

Compound 3, half-maximal cytotoxic concentration: >= 25000 nM
Compound 3: no number, only a limit (the forecaster's own chance of this, stated with the estimate: 70%); the middle value does not contradict the limit.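

In this assay compound 3 gives >= 25000 nM, which is a limit and not a number. Going by these compounds alone, the values of compound 1 and compound 2 are limits too, and no step among compound 1, compound 2 and compound 3 can be read. Still open is whether 2-(pyridin-2-yl)ethoxy and 2-(2,4,5-trifluorophenyl)ethoxy differ at all in this assay, and at what concentration any of these compounds reaches the half-maximal cytotoxic point.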